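The source may hold more compounds than are shown below. What is called first, only, known or untested is meant among the compounds shown, and "the series" means these compounds.

Measured so far: compound 1 `COc1cc(OC)c(-c2coc3cc(OCC(=O)c4cccc(C(F)(F)F)c4)ccc3c2=O)cc1OC`, compound 2 `COc1cc(OC)c(-c2coc3cc(OCc4ccc(F)cc4)ccc3c2=O)cc1OC`, compound 3 `COc1cc(OC)c(-c2coc3cc(OCc4cccc(F)c4)ccc3c2=O)cc1OC`.

In a functional assay on A-375 cells (Homo sapiens) for antiproliferative activity, read by MTT assay, with a stated time of 24 h (a higher number here means a weaker inhibitor, a lower number a stronger inhibitor), compound 2 gives 1720 nM and compound 3 gives 1300 nM. Compound 1 reaches only a limit of the assay, > 10000 nM. Compound 2 holds the higher of the two numbers; its gap to compound 3 is a 1.3-fold lower number from compound 2 to compound 3 (0.12 log units; within the scatter). Compound 4 `COc1cc(OC)c(-c2coc3cc(OCc4ccc(C(F)(F)F)cc4)ccc3c2=O)cc1OC` differs from compound 2 by trifluoromethyl in place of fluoro on an aromatic carbon. Among the compounds with values here, no measured step repeats this change. Within the data shown here, the steps of an at least 5.8-fold lower number from compound 1 to compound 2 (0.76 log units; beyond the scatter) and an at least 7.6-fold lower number from compound 1 to compound 3 (0.88 log units; beyond the scatter) remove a trifluoromethyl together with a carbonyl, and compound 1 sits at the limit of > 10000 nM in this assay, at which 1 of the 3 values shown sits, so they show only that the trifluoromethyl-bearing compound was the weaker one. A modest rise in this assay is therefore expected for compound 4, a 2.0-fold higher number from compound 2 to compound 4 (0.31 log units; beyond the scatter). Compound 4 is estimated at 3500 nM, within 1200 nM to 10000 nM.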

Compound 4, half-maximal inhibitory concentration: 2280 nM
For compound 4 the middle estimate is 1.5-fold (0.19 log units) above the measured one; low and high end bracket the measured number.
By their numbers in this assay, from the lowest: compounds 3, 2 and 4 (each within the scatter of the next). At a limit, above all of these: compound 1.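

In this assay, trifluoromethyl on this aromatic carbon, para to a large group, is accepted in place of fluoro, with a 1.3-fold higher number from compound 2 to compound 4 (0.12 log units; within the scatter). The comparison with the 3-fluorophenyl group also stays inside the scatter, with a 1.8-fold higher number from compound 3 to compound 4 (0.24 log units; within the scatter). Compound 4 retains a trifluoromethyl, yet the step reads an at least 4.3-fold lower number from compound 1 to compound 4 (0.64 log units; beyond the scatter), so trifluoromethyl as such does not go with the assay limit of compound 1: the limit of > 10000 nM in this assay, at which 1 of the 4 values shown sits.

From the compounds shown here alone, whether the carbonyl or the place of the trifluoromethyl separates compound 1 remains open. So does the response at this aromatic carbon to an amine or a carboxylic acid.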